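The source may report more compounds than this note shows. Statements on the series, on what has been measured and on what is new or still open speak of the compounds shown alone.

The series was characterised in a functional assay on U2OS cells for positive allosteric modulation of metabotropic glutamate receptor 5 (Homo sapiens), read by calcium flux, in the presence of a further agent that is not named here; on this read-out lower numbers stand for an effect already at smaller amounts and higher numbers for an effect only at larger amounts of compound. Compound 1 `Fc1ccc(-c2nc(-c3ccc4c(c3)nnn4C3CCCC3)no2)cc1` carries a cyclopentyl on the triazole nitrogen of its fused core; in this assay compound 1 gives 398 nM. Compound 2 `Fc1ccc(-c2noc(C3CCc4c(nnn4-c4ccc(F)nc4)C3)n2)cc1` places a 6-fluoropyridin-3-yl on the corresponding aromatic nitrogen of its own fused core. For compound 2 this assay reports only a limit, > 25100 nM, so no number is known for it. Thus compound 2 sits at the limit of > 25100 nM in this assay, at which 1 of the 2 values shown sits, while compound 1 has a measured value. Among the measured compounds shown here, no step between compound 1 and compound 2 is computed here, since the two differ in more than one place.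

Compound 3 `CC1(n2nnc3c2CCC(c2nc(-c4ccc(F)cc4)no2)C3)CCOCC1` is not yet measured. It differs from compound 2 by 4-methyloxan-4-yl in place of 6-fluoropyridin-3-yl on an aromatic nitrogen. For the measured compounds named here, with compound 2 known only as a limit, no measured step sets a scale for this change. Going by the values given here, the one measured compound, compound 1 with 398 nM, carries a non-aromatic ring on the same kind of nitrogen, and on that basis a move towards lower numbers is expected for compound 3, estimated as an at least 8.3-fold lower number from compound 2 to compound 3 (0.92 log units; beyond the scatter). Compound 3 is therefore expected to give about 3000 nM, within a range from 300 nM to 25100 nM.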

Compound 3, half-maximal effective concentration: 10 nM
Estimate against measurement, compound 3: 300-fold (2.48 log units) above, and the stated range ends above it.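

At the place on an aromatic nitrogen of the five-membered aromatic ring with 3 nitrogen, replacing 6-fluoropyridin-3-yl with 4-methyloxan-4-yl gives, in this assay, an at least 2500-fold lower number from compound 2 to compound 3 (3.39 log units; beyond the scatter). This shows that the group on this nitrogen can by itself decide the read-out on this core, even though the exchange leaves the number of heavy atoms and hydrogen-bond acceptors unchanged, and what differs is an aromatic ring carrying nitrogen and fluorine against a non-aromatic ring carrying oxygen and a methyl. The step is a bound and not a full measure of the change, as compound 2 is known only as a limit: the limit of > 25100 nM in this assay, at which 1 of the 3 values shown sits.

The compounds shown leave open which feature of 4-methyloxan-4-yl matters, since nothing here tells how an unsubstituted oxan-4-yl, a cyclohexyl or a tert-butyl on this nitrogen would read in this assay. Among the compounds shown here, compound 1 differs from compound 3 in more than one place and no step links them, which leaves it open how its cyclopentyl would compare with 4-methyloxan-4-yl on one and the same core.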